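This account rests on a few compounds, and the source may have more. Where it says the series, first, only, none or still open, it means among the compounds named here.

Compound 3 `O=C(Nc1cc(-c2ccccc2)nn1-c1ccccc1)c1ccc(Cl)cc1` gives 20 nM in an assay on CHO cells with metabotropic glutamate receptor 5 (Homo sapiens) as the target (on this read-out lower numbers stand for an effect already at smaller amounts and higher numbers for an effect only at larger amounts of compound), level with compound 2 `O=C(Nc1cc(-c2ccccc2)nn1-c1ccccc1)c1cccc(F)c1` at 20 nM; together they hold the lowest numbers of the three, while compound 1 `O=C(Nc1cc(-c2ccccc2)nn1-c1ccccc1)c1ccccc1` gives 40 nM. Compound 4 `O=C(Nc1cc(-c2ccccc2)nn1-c1ccccc1)c1ccccc1O` differs from compound 3 in one place: 2-hydroxyphenyl in place of 4-chlorophenyl on a carbonyl carbon. Three steps speak to this change, and all are small: a 2.0-fold lower number from compound 1 to compound 3 (0.30 log units; within the scatter), a 2.0-fold lower number from compound 1 to compound 2 (0.30 log units; within the scatter) and no change at the digits printed from compound 2 to compound 3 (within the scatter). Nothing measured shows a hydroxyphenyl on the carbonyl carbon, so the 2-hydroxyphenyl enters without a direct precedent. The shown steps suggest that this part of the molecule moves the number only within the scatter, so compound 4 is expected near compound 3, with a 2.5-fold higher number from compound 3 to compound 4 (0.40 log units; beyond the scatter). Compound 4 is therefore estimated at 50 nM, within 15 nM to 200 nM.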

Compound 4, half-maximal effective concentration: > 10000 nM
Compound 4 ended at the assay's limit; the forecaster's own chance of this, stated with the estimate: 5%; middle value at least 200-fold (2.30 log units) away from the limit.
By their numbers in this assay, from the lowest: compounds 2, 3 and 1 (each within the scatter of the next). At a limit, above all of these: compound 4.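

Going by these compounds alone, the carbonyl carbon's aryl group is not as forgiving as the earlier compounds suggested, since the 2-hydroxyphenyl gives an at least 500-fold higher number from compound 3 to compound 4 (2.69 log units; beyond the scatter) and an at least 500-fold higher number from compound 2 to compound 4 (2.69 log units; beyond the scatter). The added hydroxy alone gives an at least 250-fold higher number from compound 1 to compound 4 (2.39 log units; beyond the scatter), whereas fluoro and chloro in that kind of change stayed within the scatter. The value of compound 4 is a limit and not a number: the limit of > 10000 nM in this assay, at which 1 of the 4 values shown sits.

The compounds shown leave open whether a methoxy or an amine in place of the hydroxy would give the same result. They also leave open whether a hydroxy elsewhere on this ring would do so.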